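The source may hold more compounds than are shown below. What is called first, only, known or untested is meant among the compounds shown, and "the series" means these compounds.

Measured so far in a functional assay on U-87MG ATCC cells (Homo sapiens) for antiproliferative activity, read by MTT assay, with a stated time of 48 h; a lower number here means a stronger inhibitor, a higher number a weaker inhibitor:
compound 1 `CC(=O)Nc1nc2ccc(-c3cnc(Cl)c(NS(=O)(=O)c4ccc(F)cc4)c3)cn2n1` gives 6950 nM
compound 2 `CC(=O)Nc1nc2ccc(-c3cnc(Cl)c(NS(=O)(=O)c4ccc(C)cc4)c3)cn2n1` gives 3760 nM
compound 3 `COc1ncc(-c2ccc3nc(NC(C)=O)nn3c2)cc1NS(=O)(=O)c1ccc(F)cc1` gives 1820 nM

Among these three, compound 3 gives the lowest number in this assay; its steps to both others are beyond the scatter, so it is the strongest inhibitor of the set. Compound 4 `COc1ncc(-c2ccc3nc(NC(C)=O)nn3c2)cc1NS(=O)(=O)c1ccc(Cl)cc1` has not yet been measured. It differs from compound 3 in one place: chloro in place of fluoro on an aromatic carbon.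

Within the data shown here, one measured step bears directly on this change: a 1.8-fold lower number from compound 1 to compound 2 (0.27 log units; within the scatter), where the same para position carried methyl in place of fluoro. That step lay within the scatter, so a swap of the para substituent on that ring has so far shown no clear effect. The other step, a 3.8-fold lower number from compound 1 to compound 3 (0.58 log units; beyond the scatter), concerns a different position and does not speak to the chloro-for-fluoro change. Compound 4 is therefore expected to show a step of about a 1.2-fold lower number from compound 3 to compound 4 (0.08 log units; within the scatter), likely within the scatter, with no clear direction.

Compound 4 is estimated at 1500 nM, within 700 nM to 3500 nM.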

Compound 4, half-maximal inhibitory concentration: 2090 nM
The estimate for compound 4 lay 1.4-fold (0.14 log units) below the measured number; the measured number falls inside the stated range.
By their numbers in this assay, from the lowest: compounds 3, 4, 2 and 1 (each within the scatter of the next, the first and the last beyond it).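

In this assay, replacing 4-fluorophenyl with 4-chlorophenyl on the methoxy-bearing compounds gives a 1.1-fold higher number from compound 3 to compound 4 (0.06 log units; within the scatter), so this halogen swap does not separate the two compounds. Earlier, this ring position had been varied only with methyl in place of fluoro on the chloro-bearing compounds, as a 1.8-fold lower number from compound 1 to compound 2 (0.27 log units; within the scatter); both changes now measured there lie within the scatter, and neither compound pair goes against that reading. Nothing available explains why this position has shown so little response to these two changes.

The compounds shown leave open whether an amine or a carboxylic acid on this ring carbon would produce a step beyond the scatter. They also leave open whether chloro in place of fluoro would behave the same way on the chloro-bearing compounds.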